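The source may report more compounds than this note shows. Statements on the series, on what has been measured and on what is new or still open speak of the compounds shown alone.

Measured so far:
compound 1, `O=C(NNS(=O)(=O)c1ccccc1F)c1cc(F)cc(-n2cccn2)c1`, 334 uL/min
compound 2, `O=C(NNS(=O)(=O)c1ccccc1F)c1cc(F)cc(-c2ccccn2)c1`, 131 uL/min
compound 3, `Cc1cc(-c2ncccn2)cc(C(=O)NNS(=O)(=O)c2ccccc2)c1F`, 279 uL/min

In an ADME assay on microsomes from liver (Mus musculus) for metabolic stability, read by HPLC, using NADPH, with a stated time of 60 min, tested at 1 uM, in the presence of a further agent that is not named here (a higher number here means faster removal of the compound, a lower number slower removal), compound 3 stands second highest of the three numbers; compound 1 gives 334 uL/min, within the scatter of compound 3, while compound 2 gives 131 uL/min, beyond the scatter below it. Compound 4, `Cc1cc(-n2cccn2)cc(C(=O)NNS(=O)(=O)c2ccccc2)c1F`, differs from compound 3 by 1H-pyrazol-1-yl in place of pyrimidin-2-yl on an aromatic carbon. Among the compounds with values here, the one measured step that bears on this, a 2.5-fold lower number from compound 1 to compound 2 (0.41 log units; beyond the scatter), runs the other way: a six-membered aromatic ring with 2 hetero atoms replaced by... rather, there the 1H-pyrazol-1-yl was exchanged for a six-membered ring and the number fell. Reversing that direction, a modest rise is expected for compound 4, near the value of compound 1, giving a 1.4-fold higher number from compound 3 to compound 4 (0.16 log units; within the scatter). Compound 4 is therefore estimated at 400 uL/min, between 220 uL/min and 700 uL/min.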

Compound 4, intrinsic clearance in a liver preparation (reported as CLH), per the amount of preparation that the assay uses in the Mus musculus assay: 567 uL/min
For compound 4 the middle estimate is 1.4-fold (0.15 log units) below the measured one; the measured number falls inside the stated range.
By their numbers in the Mus musculus assay, from the lowest: compound 2; then compounds 3, 1 and 4 (each within the scatter of the next, the first and the last beyond it).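

On a different core, the Mus musculus assay gives a 2.0-fold higher number from compound 3 to compound 4 (0.31 log units; beyond the scatter), so 1H-pyrazol-1-yl again carries the higher number against a six-membered ring, as it did between compounds 1 and 2. In a physicochemical assay for solubility, read by nephelometry, in phosphate buffer, measured as kinetic solubility, at pH 6.5 (on this read-out higher numbers stand for higher solubility and lower numbers for lower solubility), compound 3 gives 50 ug/mL and compound 4 gives 6.3 ug/mL. At this aromatic carbon, then, 1H-pyrazol-1-yl goes with both faster removal and lower solubility: the measured solubility of compound 3, 50 ug/mL, and of compound 4, 6.3 ug/mL, a 7.9-fold lower number (0.90 log units; beyond the scatter)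

On these data alone, whether an amine or a carboxylic acid on this carbon would slow removal while keeping solubility remains open. The solubility finding also rests on this single pair.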